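The compounds below may be only part of what the source reports. "The series", "measured", "known", "first", "only" and "open" are said of these compounds alone.

Compound 3 `CC(C)Cn1c(=O)n(C)c(=O)c2nc(C(=O)N(C)CCCO)c(Cc3cccc4ccccc34)nc21` has no result of its own in an assay on MCF7 cells for inhibition of Monocarboxylate transporter 1 (Homo sapiens), read by scintillation counting, with a stated time of 10 min (on this read-out lower numbers stand for stronger inhibition and higher numbers for weaker inhibition), where its entry is given as "not determined" (no result reported). Compound 1 `CC(C)Cn1c(=O)n(C)c(=O)c2nc(SCCO)c(Cc3cccc4ccccc34)nc21` likewise has none, its entry in this assay being "not determined" (no result reported). For the measured compounds named here, the only number belongs to compound 2 `CC(C)Cn1c(=O)n(C)c(=O)c2nc(SCCCCO)c(Cc3cccc4ccccc34)nc21`, which in this assay gives 669 nM. Compound 4 `CC(C)Cn1c(=O)n(C)c(=O)c2nc(CCCCCO)c(Cc3cccc4ccccc34)nc21` differs from compound 3 in one place: 5-hydroxypentyl in place of (3-hydroxypropyl)(methyl)carbamoyl on an aromatic carbon. Going by the values given here, since compound 3 stands without a number, no step can be drawn from it, and the direction of the change can only be framed against compound 2, whose chain ends in the same hydroxyl and is of comparable reach. Compound 4 is therefore expected to land near compound 2, at roughly 800 nM, with a plausible range from 250 nM to 2500 nM, a result the measurement will confirm or overturn.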

Compound 4, half-maximal inhibitory concentration: 192 nM
Compound 4: the middle estimate sits 4.2-fold (0.62 log units) above what was measured; measured number outside the range, below it.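

In this assay, replacing (4-hydroxybutyl)sulfanyl with 5-hydroxypentyl on this aromatic carbon gives a 3.5-fold lower number from compound 2 to compound 4 (0.54 log units; beyond the scatter), so the position does not treat these two hydroxyl-ended chains alike. Steps involving compound 1 or compound 3 cannot be read, as neither has a number. Nothing shown accounts for this difference. From the compounds shown here alone, it remains open whether a longer chain would move the number further, and whether the terminal hydroxyl is needed or could give way to a carboxylic acid or an amine.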